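Ring Swap on the Amide Nitrogen of an Agonist Series

The compounds below may be only part of what the source reports. "The series", "measured", "known", "first", "only" and "open" are said of these compounds alone.

The measured compounds and their values:
Compound 1, `Cc1ccc2[nH]c(C(=O)N[C@H]3CN(S(=O)(=O)c4cnccn4)C[C@@H]3C(=O)NCCN(C)C)cc2c1`, gives 92% in a functional assay on HEK293 cells for agonist activity at growth hormone secretagogue receptor type 1 (Homo sapiens), read by HTRF and inositol phosphate accumulation, with a stated time of 90 min, in the presence of a further agent that is not named here; on this read-out lower numbers stand for smaller maximal responses and higher numbers for larger maximal responses.
Compound 2, `Cc1ccc2[nH]c(C(=O)N[C@H]3CN(S(=O)(=O)c4cn(C)nc4C)C[C@@H]3C(=O)NCCN(C)C)cc2c1`, gives 95% in this assay.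
Compound 3, `Cc1ccc2[nH]c(C(=O)N[C@H]3CN(S(=O)(=O)c4ccccc4)C[C@@H]3C(=O)NC[C@H]3CCCN3)cc2c1`, gives 94% in this assay.

All three share the same core and differ only in the group on the sulfonyl sulfur or on the amide-type nitrogen. Going by the values given here, the one step measured between close neighbours, a number 3 percentage points higher from compound 1 to compound 2 (within the scatter), shows that exchanging the group on the sulfonyl sulfur left the maximal response essentially unchanged. Compound 3 stands second of the three numbers, within the scatter of both compound 2 and compound 1, so the three values cannot be told apart.

Compound 4, `Cc1ccc2[nH]c(C(=O)N[C@H]3CN(S(=O)(=O)c4ccccc4)C[C@@H]3C(=O)N[C@H]3CCCNC3)cc2c1`, is not yet measured. It differs from compound 3 by piperidin-3-yl in place of (pyrrolidin-2-yl)methyl on an amide-type nitrogen. Among the compounds with values here, no measured step concerns this part of the molecule, so the only guidance is that every change seen so far, on the sulfonyl sulfur, stayed within the scatter, and that all three compounds reach a similar maximal response. The step is therefore expected to be small, a number 1 percentage points lower from compound 3 to compound 4 (within the scatter), with no direction beyond the scatter. Compound 4 is estimated at 93%, likely between 80% and 102%.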

Compound 4, largest response reached (Emax), in percent of the reference or control that the assay uses: 98%
Estimate against measurement, compound 4: 5 percentage points below; low and high end bracket the measured number.
By their numbers in this assay, from the lowest: compounds 1, 3, 2 and 4 (each within the scatter of the next).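

Going by these compounds alone, this is the first measured step at the amide-type nitrogen rather than on the sulfonyl sulfur, and in this assay it reads a number 4 percentage points higher from compound 3 to compound 4 (within the scatter) and so gives no real difference in maximal response. The piperidin-3-yl group brings the amine nitrogen into a six-membered ring attached directly to the amide-type nitrogen, whereas the (pyrrolidin-2-yl)methyl group holds a five-membered ring one carbon further out, and this rearrangement of the same atoms leaves the response within the usual scatter. No measured evidence is available that could explain this result.

From the compounds shown here alone, it remains open how the response would change with a cyclohexyl ring, which has no ring nitrogen, or with a carboxylic acid on this amide-type nitrogen, as both replace the amine present in compound 3 and compound 4. Also open, going by these compounds, is whether piperidin-3-yl would give a similar response with pyrazin-2-yl or 1,3-dimethyl-1H-pyrazol-4-yl on the sulfonyl sulfur, and how much compound each structure needs to reach its maximal response.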